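A few compounds are considered here, and "the series" means these few. Any claim that something is new, unique, unknown or untested is made for them only; others in the source may bear on it.

Measured compounds:
Compound 1 `CN(C)c1nc(N)c2ncn([C@@H]3C[C@@H](O)[C@H](CO)O3)c2n1`: in a functional assay on NALL-1 cells (Homo sapiens) (on this read-out higher numbers stand for weaker inhibition and lower numbers for stronger inhibition), compound 1 gives > 300 uM, a limit of the assay rather than a number.
Compound 2 `CSc1nc(SC)c2ncn([C@@H]3C[C@@H](O)[C@H](CO)O3)c2n1`: in this assay compound 2 gives 173 uM.
Compound 3 `CSc1nc(N(C)C)c2ncn([C@@H]3C[C@@H](O)[C@H](CO)O3)c2n1`: in this assay compound 3 gives 188 uM.

Among the three, compound 1 is the one that sits at the limit of > 300 uM in this assay, at which 1 of the 3 values shown sits, while compound 2 and compound 3 have numbers in this assay that lie within the scatter of each other. Compound 4 `CSc1nc(N)c2ncn([C@@H]3C[C@@H](O)[C@H](CO)O3)c2n1` differs from compound 1 in one place: methylsulfanyl in place of dimethylamino on an aromatic carbon. Going by the values given here, one measured step bears on this change, and it runs the opposite way: a 1.1-fold higher number from compound 2 to compound 3 (0.04 log units; within the scatter), a step within the scatter. The same exchange in the forward direction is therefore expected to move compound 1 little in this assay, and since compound 1 is known only as a limit, compound 4 may well be reported as a limit again. Compound 4 is estimated at 300 uM, with a range from 120 uM to 800 uM. The step of a number no higher from compound 1 to compound 4 (the limit leaves the size open) is accordingly expected to stay within the scatter.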

Compound 4, concentration for 50% inhibition: 96 uM
For compound 4 the middle estimate is 3.1-fold (0.49 log units) above the measured one, and the stated range ends above it.
By their numbers in this assay, from the lowest: compounds 4, 2 and 3 (each within the scatter of the next). At a limit, above all of these: compound 1.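

At this aromatic carbon between two ring nitrogen atoms, methylsulfanyl in place of dimethylamino is not neutral on every core in this assay: with an amino group on the ring the exchange gives an at least 3.1-fold lower number from compound 1 to compound 4 (0.49 log units; beyond the scatter), and it reads differently on the two cores: the same change on two cores in this assay, a 1.1-fold higher number (0.04 log units; within the scatter) from compound 2 to compound 3 and an at least 3.1-fold higher number (0.49 log units; beyond the scatter) from compound 4 to compound 1, at least 2.8-fold (0.45 log units) apart, beyond the scatter of two such steps. Compound 1 stands at a limit of the assay, > 300 uM, so that step has no upper end. The other two steps, a 2.0-fold lower number from compound 3 to compound 4 (0.29 log units; within the scatter) and a 1.8-fold lower number from compound 2 to compound 4 (0.26 log units; within the scatter), lie within the scatter, which leaves these three values not set apart.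

Still open, on these data alone, is the true size of the exchange on the amino-bearing core. Also open, as far as these compounds go, is whether ethylsulfanyl or methylamino on this carbon would behave like methylsulfanyl or like dimethylamino.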